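The source may hold more compounds than are shown below. What is called first, only, known or untested is meant among the compounds shown, and "the series" means these compounds.

Measured so far in a functional assay on the whole organism for inhibition, with Mus musculus as the target, with a stated time of 4 h, at a dose of 50 mg/kg by the oral route; on this read-out higher numbers stand for more inhibition at the one dose given (going by the name of the read-out) and lower numbers for less inhibition:
Compound 1 `Cc1ccc(-c2c(S(=O)(=O)c3ccccc3)cnc3ncnn23)cc1` gives 3.3%.
Compound 2 `O=S(=O)(c1ccccc1)c1cnc2ncnn2c1-c1ccc(Br)cc1` gives 1.3%.
Compound 3 `Cc1ccc(-c2c(S(=O)(=O)c3ccccc3)cnc3cc(-c4ccc(Br)cc4)nn23)cc1` gives 26.6%.

Compound 2 and compound 1 share one core and differ only by methyl in place of bromo on an aromatic carbon. The step that this change made is a number 2 percentage points higher from compound 2 to compound 1 (within the scatter). Compound 3 carries a different core from compound 2; the difference between the two cores is not broken down here. Compound 3 stands highest of the three numbers, beyond the scatter from both compound 1 and compound 2.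

Compound 4 `Cc1ccc(-c2cc3ncc(S(=O)(=O)c4ccccc4)c(-c4ccc(C)cc4)n3n2)cc1` is not yet measured. It differs from compound 3 by methyl in place of bromo on an aromatic carbon, the same change as that between compound 2 and compound 1, at a place described in the same words. This change occurs twice among the compounds shown. Because the earlier step of a number 2 percentage points higher from compound 2 to compound 1 (within the scatter) stayed within the scatter, compound 4 is expected in this assay to stay close to compound 3, with an expected step of a number 1.4 percentage points higher from compound 3 to compound 4 (within the scatter). Compound 4 is therefore estimated at 28%, with a likely range from 14% to 42%. The measurement itself is still to come.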

Compound 4, a percentage reported as inhibition, in the whole organism at one dose (the size of the read-out at that dose, not a potency): 20%
For compound 4 the middle estimate is 8 percentage points above the measured one, and the stated range covers the measured number.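

In this assay, the change from 4-bromophenyl to 4-methylphenyl gives a number 6.6 percentage points lower from compound 3 to compound 4 (within the scatter), and the same change on the other core gives a number 2 percentage points higher from compound 2 to compound 1 (within the scatter). Set side by side, the two steps cannot be told apart: the same change on two cores in this assay, a number 2 percentage points higher (within the scatter) from compound 2 to compound 1 and a number 6.6 percentage points lower (within the scatter) from compound 3 to compound 4, 8.6 percentage points apart, within the scatter of two such steps. In the two pairs shown, this change therefore carries from one core to the other without a step beyond the scatter, but two pairs at one dose and one time do not show that the change is neutral on every core in the series, nor do they measure potency.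

The compounds shown leave open whether an amine, a carboxylic acid or a longer chain in place of the methyl on that aromatic carbon would give a step beyond the scatter in this assay. Within the data shown here, they also leave open whether such a group would behave alike on both cores, since bromo and methyl are the only groups compared there.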